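Cytotoxicity of a cyclopentyl ether and its dichlorophenyl analogue

A few compounds are considered here, and "the series" means these few. Any claim that something is new, unique, unknown or untested is made for them only; others in the source may bear on it.

The starting point is compound 1 `Cc1cn(C2CCN(Cc3cccc(OC4CCCC4)c3)CC2)c(=O)[nH]c1=O`, tested in an ADME assay on MRC5 cells (Homo sapiens) for cytotoxicity, read by fluorescence and resazurin assay, with a stated time of 3 days (a higher number here means a weaker inhibitor, a lower number a stronger inhibitor), where compound 1 gives 30300 nM. Among the compounds with values here, this is the only number in the set: compound 2 `Cc1cn(C2CCN(Cc3cc(Oc4cc(Cl)cc(Cl)c4)ccn3)CC2)c(=O)[nH]c1=O` was also entered in this assay but compound 2 gives "not determined" (no result reported), so nothing can be compared against compound 1, and compound 1 stands as the single measured point.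

Compound 3 `Cc1cn(C2CCN(Cc3cccc(Oc4ccc(Cl)c(Cl)c4)c3)CC2)c(=O)[nH]c1=O` has not yet been measured in this assay. Its difference from compound 1 is 3,4-dichlorophenyl in place of cyclopentyl on an oxygen on an aromatic ring. Within the data shown here, no step between two measured compounds is available, so the size of the change can only be judged from the structural swap itself. The expectation is that compound 3 is a somewhat stronger inhibitor than compound 1, with an estimated step of a 2.0-fold lower number from compound 1 to compound 3 (0.31 log units; beyond the scatter), a move that may or may not exceed the usual scatter. In this assay compound 3 is therefore estimated at 15000 nM, with a plausible range from 5000 nM to 45000 nM.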

Compound 3, half-maximal inhibitory concentration: 6100 nM
For compound 3 the middle estimate is 2.5-fold (0.39 log units) above the measured one; the measured number falls inside the stated range.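

In this assay, within the data shown here, the oxygen on the aromatic ring turns out to be a place where the group matters: replacing cyclopentyl with 3,4-dichlorophenyl gives a 5.0-fold lower number from compound 1 to compound 3 (0.70 log units; beyond the scatter), the first change in this set that can be read as a step and one that lies beyond the usual scatter. The counted hydrogen-bond donors, hydrogen-bond acceptors and net charge are the same for both groups, yet the swap changes several things at once, bringing in more heavy atoms, an aromatic ring in place of a non-aromatic one, and two chlorine atoms, so this single step cannot assign the shift to any one of them. Nothing available explains the shift in cell toxicity.

On these data alone, compound 2 has no number, so any step involving it cannot be read, and the effect of its different arrangement of the two chlorines on an otherwise related scaffold stays unknown. The compounds shown also leave open whether a plain phenyl without chlorine, or a group of another kind on the same oxygen such as an amine-bearing chain or a carboxylic acid, would move the number in the same direction.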